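The compounds below may be only part of what the source reports. "The series", "measured", "known", "first", "only" and "open" are said of these compounds alone.

Compound 1 `O=C(NCCCNc1nccc(-c2c(-c3cccc(F)c3)nc3sccn23)n1)c1ccc(F)cc1` carries a (4-fluorophenyl)carbonyl amide on the chain amine. In a functional assay on SK-MEL-28 cells (Homo sapiens) for cytotoxicity, read by MTT assay (a higher number here means a weaker inhibitor, a lower number a stronger inhibitor), compound 1 gives > 20000 nM, which is a limit of the assay rather than a number. Two of the three values gathered so far sit at the limit of > 20000 nM in this assay, at which 2 of the 3 values shown sit, so compound 1 stands among the weakest members but cannot be placed more exactly. Compound 2 `O=S(=O)(NCCCNc1nccc(-c2c(-c3cccc(F)c3)nc3sccn23)n1)c1ccccc1` gives 6850 nM in this assay. Compound 3 `O=C(NCCCNc1nccc(-c2c(-c3cccc(F)c3)nc3sccn23)n1)c1ccc(Cl)cc1` gives > 20000 nM in this assay, again a limit.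

The move to compound 4 `O=S(=O)(NCCNc1nccc(-c2c(-c3cccc(F)c3)nc3sccn23)n1)c1ccc(Br)cc1` is ((4-bromophenyl)sulfonyl)amino in place of (((4-fluorophenyl)carbonyl)amino)methyl on a saturated chain carbon, two bonds along the chain from a nitrogen on an aromatic ring. The step that bears on it is an at least 2.9-fold lower number from compound 1 to compound 2 (0.46 log units; beyond the scatter), where a sulfonyl took the place of a carbonyl; the reverse step, an at least 2.9-fold higher number from compound 2 to compound 3 (0.46 log units; beyond the scatter), points the same way. Going by the values given here, the bromo substituent and the shortened linker have no measured counterpart in this set, so their share is unknown. Compound 4 is therefore expected to show a step of an at least 2.8-fold lower number from compound 1 to compound 4 (0.45 log units; beyond the scatter), resting on an at least 2.9-fold lower number from compound 1 to compound 2 (0.46 log units; beyond the scatter). The estimate for compound 4 is 7000 nM, within 2500 nM to 20000 nM.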

Compound 4, half-maximal inhibitory concentration: 13500 nM
The estimate for compound 4 lay 1.9-fold (0.29 log units) below the measured number, and the stated range covers the measured number.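

In this assay, compound 4 cannot be told apart from the other sulfonamide: a 2.0-fold higher number from compound 2 to compound 4 (0.29 log units; within the scatter). Replacing ((phenylsulfonyl)amino)methyl with ((4-bromophenyl)sulfonyl)amino at this saturated chain carbon therefore gives no readable shift, and the sulfonamide now appears in two compounds with values that can be read as numbers. Against the amides the result is less firm, with an at least 1.4-fold lower number from compound 1 to compound 4 (0.17 log units; that floor lies within the scatter) and an at least 1.4-fold lower number from compound 3 to compound 4 (0.17 log units; that floor lies within the scatter), and these steps are only floors set by limits of the assay: the limit of > 20000 nM in this assay, at which 2 of the 4 values shown sit.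

As far as these compounds go, the bromo substituent and the change in the chain arrive together in compound 4, so their separate shares, and whether they offset each other, stay open. Also open, from the compounds shown here alone, is how an amine, a carboxylic acid or a longer chain at this position would read.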